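Solubility notes on three measured compounds and one pending

This account rests on a few compounds, and the source may have more. Where it says the series, first, only, none or still open, it means among the compounds named here.

Measured in a physicochemical assay for solubility, in phosphate buffer, with a stated time of 18 h, at pH 7.4; a higher number here means a more soluble compound, a lower number a less soluble compound: compound 1 `Nc1nc(-c2ccccc2)nn1-c1ncnc2ccccc12` gives 1000 nM; compound 2 `COc1cc2ncnc(-n3nc(N)nc3N)c2cc1OC` gives 83000 nM; compound 3 `COc1cc2ncnc(-n3nc(-c4ccccn4)nc3N)c2cc1OCCCN1CC(C)OC(C)C1` gives 8000 nM.

Compound 3 holds the middle place of the three: its number sits beyond the scatter from compound 1 on the low side and from compound 2 on the high side. Within the data shown here, no two of the measured compounds differ in one place only, so no single step is known from measurement. Compound 4 `COc1cc2ncnc(-n3nc(-c4ccccn4)nc3N)c2cc1OCCCNC(=O)OCC(C)(C)C` is compound 3 with one change: (neopentyloxycarbonyl)amino in place of 2,6-dimethylmorpholin-4-yl on a saturated chain carbon, three bonds along the chain from an oxygen on an aromatic ring. Among the measured compounds shown here, on this change alone, with no measured step to lean on, a decrease in this assay beyond the scatter is expected, of the size a 4.0-fold lower number from compound 3 to compound 4 (0.60 log units; beyond the scatter). Compound 4 is accordingly estimated at 2000 nM, within 500 nM to 8000 nM.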

Compound 4, solubility: 200 nM
For compound 4 the middle estimate is 10-fold (1.00 log units) above the measured one, and the stated range ends above it.
By their numbers in this assay, from the lowest: compound 4; then compound 1; then compound 3; then compound 2.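

In this assay, the group at the end of the 3-carbon-free chain position is now shown to matter: (neopentyloxycarbonyl)amino in place of 2,6-dimethylmorpholin-4-yl gives a 40-fold lower number from compound 3 to compound 4 (1.60 log units; beyond the scatter), a large step and the first single change in the series with a measured size. The step is one change at one place, so it fixes a size for this pair only. Nothing measured here gives a reason for the drop.

Open, going by these compounds, is how a primary amine or a carboxylic acid would read on the same saturated chain carbon. Also open, on these data alone, is whether a longer chain would keep this step at the same size.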